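The source may hold more compounds than are shown below. What is called first, only, known or untested is meant among the compounds shown, and "the series" means these compounds.

Working notes on the series.

Compound 1 `CN(C(=O)NC(=O)c1ccccc1F)c1nc(C(F)(F)F)c(C(=O)N/N=C/c2cc(C(F)(F)F)cc(C(F)(F)F)c2)s1` is the reference point. In a functional assay on BCG823 cells (Homo sapiens) for inhibition, read by MTT assay, with a stated time of 72 h (on this read-out higher numbers stand for weaker inhibition and lower numbers for stronger inhibition), compound 1 gives 4.23 ug/mL, the only numerical result obtained so far in the set. Compound 2 `CNc1nc(C)c(C(=O)N/N=C/c2cc(C(F)(F)F)cc(C(F)(F)F)c2)s1` belongs to the same series but carries a different substitution pattern on the shared core and on the amine. For compound 2 the result in this assay is a limit, > 100 ug/mL, and not a number. For the measured compounds named here, this sits at the limit of > 100 ug/mL in this assay, at which 1 of the 2 values shown sits, so the two compounds show only that compound 1 reaches a measurable value where compound 2 does not; no measured step between them is available.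

Compound 3 `CN(C(=O)NC(=O)c1ccc(Cl)cc1Cl)c1nc(C(F)(F)F)c(C(=O)N/N=C/c2cc(C(F)(F)F)cc(C(F)(F)F)c2)s1` keeps everything of compound 1 except the aryl group of the acyl urea: 2,4-dichlorophenyl in place of 2-fluorophenyl on a carbonyl carbon. There is no measured step of this kind in the series, so the expectation rests on compound 1 alone. The step is expected to be small, within or near the scatter of this assay, with no clear direction: a 1.1-fold lower number from compound 1 to compound 3 (0.02 log units; within the scatter). Compound 3 is therefore estimated at 4 ug/mL, with a range from 1.5 ug/mL to 12 ug/mL.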

Compound 3, half-maximal inhibitory concentration: > 100 ug/mL
Compound 3 was reported as a limit; the forecaster's own chance of this, stated with the estimate: 5%; middle value at least 25-fold (1.39 log units) from the limit.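

The exchange of 2-fluorophenyl for 2,4-dichlorophenyl on a carbonyl carbon gives an at least 23-fold higher number from compound 1 to compound 3 (1.37 log units; beyond the scatter) in this assay, so this aryl group is not a neutral place in the series, and a change that looks modest on paper can be enough to lose a measurable value. Compound 3 keeps everything else of compound 1, which ties the change to this single place, something the earlier pair could not do, since compound 2 differs from compound 1 in more than one place. The result for compound 3 is a limit and not a number, so the step gives only a lower bound on its size, and the set now gathers at that limit: the limit of > 100 ug/mL in this assay, at which 2 of the 3 values shown sit.

The compounds shown leave open which part of the change matters, since a 2-chlorophenyl, a 4-chlorophenyl or an unsubstituted phenyl on the same carbonyl carbon would each separate the two chlorine atoms from the loss of the fluorine. They also leave open how far this place tolerates other groups, such as a 4-methoxyphenyl or a pyridyl ring, and whether any of them gives a number in this assay.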